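The source may report more compounds than this note shows. Statements on the series, on what has been measured and on what is new or still open speak of the compounds shown alone.

Compound 1 `C=C[C@@](C)(/C=C/c1ccc(O)c(/C=C/C(=O)OCC)c1)CCC=C(C)C`: 20900 nM
Compound 2 `C=C[C@@](C)(/C=C/c1ccc(O)c(/C=C/C(N)=O)c1)CCC=C(C)C`: > 43400 nM, a limit
Compound 3 `C=C[C@@](C)(/C=C/c1ccc(O)c(/C=C/c2ccc(F)cc2)c1)CCC=C(C)C`: > 43400 nM, a limit

These compounds share a core and were tested in a functional assay on NALM-6 cells (Homo sapiens) for cytotoxicity, with a stated time of 72 h; on this read-out lower numbers stand for an effect already at smaller amounts and higher numbers for an effect only at larger amounts of compound. Of the three, only compound 1 gives an actual number, 20900 nM. Compound 3 has no number of its own, and it stands at the limit of > 43400 nM in this assay, at which 2 of the 3 values shown sit.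

Compound 4 `C=C[C@@](C)(/C=C/c1ccc(O)c(/C=C/c2ccc(Cl)c(Cl)c2)c1)CCC=C(C)C` differs from compound 3 in one group: 3,4-dichlorophenyl in place of 4-fluorophenyl on a double-bonded chain carbon bound to a double-bonded chain carbon. Within the data shown here, the swap exchanges one substituted phenyl group for another, and no measured step does that directly. The nearest evidence comes from changes at the same chain carbon. Placing 4-fluorophenyl there instead of ethoxycarbonyl gave an at least 2.0-fold higher number from compound 1 to compound 3 (0.31 log units; beyond the scatter). A change within the ethoxycarbonyl group itself, amino in place of ethoxy, gave an at least 2.0-fold higher number from compound 1 to compound 2 (0.31 log units; beyond the scatter). Going by these compounds, both steps go beyond the scatter, but their true sizes remain open. The remaining comparison, a step that the two limits leave unreadable from compound 2 to compound 3, tells nothing about size.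

With so little to go on, only a small shift is expected. The expected change, an at least 1.2-fold lower number from compound 3 to compound 4 (0.09 log units; that floor lies within the scatter), points towards lower numbers, though compound 4 may well return only a limit again. For compound 4 the estimated value is 35000 nM, with an expected range from 12000 nM to 60000 nM.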

Compound 4, half-maximal effective concentration: 7510 nM
Compound 4: middle estimate off by 4.7-fold (0.67 log units), on the high side; measured number below the stated range.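

This chain carbon turns out to be sensitive to which substituted phenyl group it carries: in this assay, replacing 4-fluorophenyl with 3,4-dichlorophenyl gives an at least 5.7-fold lower number from compound 3 to compound 4 (0.76 log units; beyond the scatter). A phenyl group at this carbon is therefore not tied to a loss of effect, since the 3,4-dichlorophenyl group also outdoes ethoxycarbonyl, with a 2.8-fold lower number from compound 1 to compound 4 (0.44 log units; beyond the scatter), and carbamoyl, with an at least 5.7-fold lower number from compound 2 to compound 4 (0.76 log units; beyond the scatter), leaving compound 4 with the lowest number of the series. The steps starting at compound 2 and compound 3 give only floors for their true sizes, because both compounds stand at a limit: the limit of > 43400 nM in this assay, at which 2 of the 4 values shown sit.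

What a single chlorine would do at this carbon stays open, as the compounds shown cannot tell whether a 3-chlorophenyl or a 4-chlorophenyl group would match the 3,4-dichlorophenyl group or fall back towards the 4-fluorophenyl group. Also unknown is how far the trend with rings at this carbon extends, for instance to an unsubstituted phenyl group, a 3,4-dibromophenyl group or a pyridine ring.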